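This account rests on a few compounds, and the source may have more. Where it says the series, first, only, none or still open, it means among the compounds named here.

Compound 1 `O=C(/C=C/[C@H]1C[C@@H](O)[C@@H](O)C1)Nc1ccccc1` stands at a limit in an ADME assay on S2 cells (Drosophila melanogaster) for cytotoxicity, read by MTT assay; on this read-out lower numbers stand for an effect already at smaller amounts and higher numbers for an effect only at larger amounts of compound: there compound 1 gives > 200000 nM, which is a limit and not a number. Compound 2 `CNC(=O)/C=C/[C@H]1C[C@@H](O)[C@@H](O)C1` also sits at a limit, giving > 250000 nM in this assay. The step that the two limits leave unreadable from compound 1 to compound 2 is therefore not readable. Compound 3 `Cc1ccc(NC(=O)/C=C/[C@H]2C[C@@H](O)[C@@H](O)C2)cc1` differs from compound 1 by methyl in place of hydrogen on an aromatic carbon. Within the data shown here, no measured step speaks to this change, since the one neighbouring step cannot be read, so no shift beyond the scatter is expected; the expected step is a step that the limit leaves unreadable from compound 1 to compound 3. Compound 3 is estimated at 250000 nM, with a range from 120000 nM to 500000 nM.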

Compound 3, half-maximal effective concentration: > 190000 nM
Compound 3 was reported as a limit; the forecaster's own chance of this, stated with the estimate: 75%; the middle value lies beyond the limit too.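

In this assay compound 3 gives > 190000 nM, which is a limit and not a number. Compound 1 also stands at a limit, so the step between compound 1 and compound 3 cannot be read. The compounds shown leave open whether methyl in place of hydrogen on an aromatic carbon shifts this read-out at all.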